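The compounds below may be only part of what the source reports. "The series", "measured", "known", "first", "only" and "open" are said of these compounds alone.

Measured so far:
- compound 1 `CCCCCCCCCCCCCCCCc1c(C)c(N(C)C)nc(C)c1O`: in a functional assay on cells (Lymphocyte, Homo sapiens), read by trypan blue exclusion, with a stated time of 16 h, tested at 2.5 uM (on this read-out lower numbers stand for a weaker effect and higher numbers for a stronger effect at the one concentration tested), compound 1 gives 85%
- compound 2 `CCCCCCCCCCc1c(C)c(N(C)C)nc(C)c1O`: in this assay compound 2 gives 86%

Compound 1 stands at the lower of the two numbers, but its nearest neighbour is compound 2, and the step of a number 1 percentage points higher from compound 1 to compound 2 (within the scatter) is within the scatter, so the two cannot be told apart on this read-out.

Compound 3 `CCCCCCCCCCCCCCCCc1c(C)c(N2CCC2)nc(C)c1O` has not yet been measured. It differs from compound 1 in one place: azetidin-1-yl in place of dimethylamino on an aromatic carbon. Among the measured compounds shown here, the only measured step, from compound 1 to compound 2, changes the long chain and not the group on the ring carbon, so it does not bear on this change. For the measured compounds named here, there is no measured pair in which the group on that ring carbon is exchanged, so the data give no direction for the step.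

Given that the one measured step was within the scatter, compound 3 is expected to stay close to compound 1, with a step of a number 1 percentage points lower from compound 1 to compound 3 (within the scatter). The estimate for compound 3 in this assay is 84%, with a range from 65% to 95%.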

Compound 3, a percentage reported as activity, at one concentration (the size of the read-out at that concentration, not a potency): 92%
For compound 3 the middle estimate is 8 percentage points below the measured one; the measured number falls inside the stated range.
By their numbers in this assay, from the lowest: compounds 1, 2 and 3 (each within the scatter of the next).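

In this assay, among the compounds shown here, the exchange of dimethylamino for azetidin-1-yl on the aromatic carbon next to the ring nitrogen gives the first measured step at this position, a number 7 percentage points higher from compound 1 to compound 3 (within the scatter), whereas the earlier pair differed only in the long chain. This shows that closing the two open carbons of the amine into a four-membered ring, with 4 heavy atoms in place of 3, leaves the read-out indistinguishable from that of compound 1, so the position accepts this change without a change that the assay can detect. No measurement is available that would explain this result.

With a single exchange at this position, and at one concentration, the compounds shown leave open whether the same holds for a larger ring amine such as piperidin-1-yl or morpholin-4-yl, or for a plain primary amine on the same carbon. They also leave open whether any group at this position matters at all in this assay, and whether a methoxy group in place of the hydroxy group would give a number outside the scatter.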